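A few compounds are considered here, and "the series" means these few. Any claim that something is new, unique, unknown or untested is made for them only; others in the source may bear on it.

Of the compounds shown here, three sharing one core have been measured in a functional assay on FM3A cells (Mus musculus) for inhibition, read by cell counting, with a stated time of 2 days; a lower number here means a stronger inhibitor, a higher number a weaker inhibitor. Compound 1 `C=C(Br)C(=O)Nc1cccc(-c2cn3nc(Cc4cccc(OC)c4)sc3n2)c1` gives 1100 nM, compound 2 `C=C(Br)C(=O)Nc1cccc(-c2cn3nc(-c4ccccc4)sc3n2)c1` gives 900 nM, and compound 3 `C=C(Br)C(=O)Nc1cccc(-c2cn3nc(-c4cccs4)sc3n2)c1` gives 370 nM. Compound 3 therefore stands lowest of the three, and since its steps to both others lie beyond the scatter, it is the strongest inhibitor so far: the change is a 2.4-fold lower number from compound 2 to compound 3 (0.39 log units; beyond the scatter) and a 3.0-fold lower number from compound 1 to compound 3 (0.47 log units; beyond the scatter), while the step of a 1.2-fold lower number from compound 1 to compound 2 (0.09 log units; within the scatter) between the two weaker compounds is within the scatter.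

Compound 4 `C=C(Br)C(=O)Nc1cccc(-c2cn3nc(-c4ccc(OC)cc4)sc3n2)c1` has not been measured. It differs from compound 3 in one place: 4-methoxyphenyl in place of thiophen-2-yl on an aromatic carbon. Within the data shown here, the step that bears most directly on this is the one from compound 2 to compound 3, where thiophen-2-yl replaced phenyl and brought a 2.4-fold lower number from compound 2 to compound 3 (0.39 log units; beyond the scatter); compound 4 undoes that replacement and adds a methoxy group to the phenyl ring. Among the measured compounds shown here, nothing among the measured pairs shows what a methoxy group on that phenyl does on its own, so the expectation is simply a return toward the level of compound 2. In this assay compound 4 is therefore expected to show a modest step upward, a 2.4-fold higher number from compound 3 to compound 4 (0.39 log units; beyond the scatter), and is estimated at 900 nM, with a likely range from 400 nM to 2000 nM.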

Compound 4, half-maximal inhibitory concentration: 890 nM
For compound 4 the middle estimate is 1.0-fold (0.00 log units) above the measured one; measured number inside the range.
By their numbers in this assay, from the lowest: compound 3; then compounds 4, 2 and 1 (each within the scatter of the next).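

In this assay, a methoxy group on the phenyl ring at this carbon of the shared core, next to the ring nitrogen and the ring sulfur, makes no readable difference, with a 1.0-fold lower number from compound 2 to compound 4 (0.00 log units; within the scatter), and 4-methoxyphenyl also cannot be told apart from 3-methoxybenzyl, with a 1.2-fold lower number from compound 1 to compound 4 (0.09 log units; within the scatter). Thiophen-2-yl now stands clear of a second phenyl-based group as well, with a 2.4-fold higher number from compound 3 to compound 4 (0.38 log units; beyond the scatter), so its advantage no longer rests on the comparison with plain phenyl alone, and compound 3 remains the strongest inhibitor of the four. Nothing available here explains why the five-membered sulfur ring gives the lower number at this position. The compounds shown leave open whether the advantage belongs to thiophen-2-yl specifically or extends to related rings such as furan-2-yl or thiophen-3-yl, and whether a methoxy group on the thiophene ring would matter there when it does not on phenyl. They also say nothing about how a quite different group at this carbon, such as an amine, a carboxylic acid or a longer alkyl chain, would behave.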